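A few compounds are considered here, and "the series" means these few. Any claim that something is new, unique, unknown or untested is made for them only; others in the source may bear on it.

Measured so far in a functional assay on SW-620 cells (Homo sapiens) for antiproliferative activity, with a stated time of 48 h; a lower number here means a stronger inhibitor of growth, a higher number a weaker inhibitor of growth:
Compound 1, `Cc1cc(O)c(C2=NN(c3ccc(S(N)(=O)=O)cc3)C(/C=C/c3ccccc3)C2)cc1Cl`, gives 31300 nM.
Compound 2, `COc1ccc(C2CC(c3cc(Cl)c(C)cc3O)=NN2c2ccc(S(N)(=O)=O)cc2)cc1OC`, gives 26600 nM.

Compound 2 shows the smaller of these two numbers, but the step of a 1.2-fold lower number from compound 1 to compound 2 (0.07 log units; within the scatter) lies within the scatter, so the two compounds cannot be ranked against each other as growth inhibitors.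

Compound 3, `COc1ccc(C2CC(c3cc(Cl)c(C)cc3O)=NN2c2ccc(S(N)(=O)=O)cc2)c(OC)c1OC`, differs from compound 2 in a single place: methoxy in place of hydrogen on an aromatic carbon. Among the measured compounds shown here, no measured step adds a methoxy group to this part of the molecule. For the measured compounds named here, the only step available, a 1.2-fold lower number from compound 1 to compound 2 (0.07 log units; within the scatter), exchanges a whole side group and itself stayed within the scatter, so it gives no direct guide to the change at hand and no reason to expect a large move in either direction.

Compound 3 is therefore expected to stay close to compound 2, with the step of a 1.1-fold lower number from compound 2 to compound 3 (0.03 log units; within the scatter) estimated to fall within the scatter. Compound 3 is estimated at 25000 nM, in a range from 10000 nM to 60000 nM.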

Compound 3, concentration for total growth inhibition: 10700 nM
Estimate against measurement, compound 3: 2.3-fold (0.37 log units) above, and the stated range covers the measured number.
By their numbers in this assay, from the lowest: compound 3; then compounds 2 and 1 (each within the scatter of the next).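

In this assay, one added methoxy group on an aromatic carbon, ortho to a large group, turns 3,4-dimethoxyphenyl into 2,3,4-trimethoxyphenyl and gives a 2.5-fold lower number from compound 2 to compound 3 (0.40 log units; beyond the scatter) and so shows that a change this small at this position can move the number beyond the scatter, which the earlier exchange of a whole side group did not do. The 2,3,4-trimethoxyphenyl group can also be told apart from 2-phenylethenyl, with a 2.9-fold lower number from compound 1 to compound 3 (0.47 log units; beyond the scatter) as the step between them. No measurement here accounts for the stronger growth inhibition.

From the compounds shown here alone, it remains open whether an amine, a fluorine atom or a longer chain such as ethoxy at this position would lower the number further or raise it again. Going by these compounds, it is also open whether the new methoxy group would give a similar step without the two methoxy groups already on the ring.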